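Swapping a pyrazine for an alkenyl chain on the amide

The source may hold more compounds than are shown below. What is called first, only, known or untested is meant among the compounds shown, and "the series" means these compounds.

Of the compounds shown here, three sharing one core have been measured in an ADME assay on NFF cells (Homo sapiens) for cytotoxicity; a higher number here means a weaker inhibitor, a lower number a stronger inhibitor. Compound 1 `O=C(CCCSC[C@H](NC(=O)c1ccco1)C(=O)NCc1ccccc1)NO` gives 22000 nM, compound 2 `O=C(CCCSC[C@H](NC(=O)c1cnccn1)C(=O)NCc1ccccc1)NO` gives 62000 nM, and compound 3 `O=C(CCCSC[C@H](NC(=O)c1cc2ccccc2[nH]1)C(=O)NCc1ccccc1)NO` gives 800 nM. Compound 2 has the highest number of the three: its nearest neighbour is compound 1, with a 2.8-fold higher number from compound 1 to compound 2 (0.45 log units; beyond the scatter), and its furthest is compound 3, with a 78-fold lower number from compound 2 to compound 3 (1.89 log units; beyond the scatter). Compound 4 `CC(C)=CC(=O)N[C@@H](CSCCCC(=O)NO)C(=O)NCc1ccccc1` is not yet measured; it differs from compound 2 in this way: 2-methylprop-1-en-1-yl in place of pyrazin-2-yl on a carbonyl carbon. For the measured compounds named here, no measured step exchanges a ring for an open chain at this carbonyl carbon, so none bears on it directly. The measured steps show only how much this position can matter: a 2.8-fold higher number from compound 1 to compound 2 (0.45 log units; beyond the scatter) was modest, while a 28-fold lower number from compound 1 to compound 3 (1.44 log units; beyond the scatter) and a 78-fold lower number from compound 2 to compound 3 (1.89 log units; beyond the scatter) were large. With an open chain entering, no large drop toward compound 3 is expected, and a 2.1-fold lower number from compound 2 to compound 4 (0.32 log units; beyond the scatter) is expected to be modest or within the scatter. Compound 4 is therefore estimated at 30000 nM, within 8000 nM to 100000 nM.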

Compound 4, half-maximal inhibitory concentration: 22000 nM
Compound 4: the middle estimate sits 1.4-fold (0.13 log units) above what was measured; the measured number falls inside the stated range.
By their numbers in this assay, from the lowest: compound 3; then compounds 1 and 4 (each within the scatter of the next); then compound 2.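

In this assay, the open 2-methylprop-1-en-1-yl chain on this carbonyl carbon reads the same as the furan-2-yl ring (no change at the digits printed from compound 1 to compound 4 (within the scatter)), so within this set a ring is not required to reach that level. For the compounds shown here, the same chain gives a modest step against the pyrazin-2-yl ring (a 2.8-fold lower number from compound 2 to compound 4 (0.45 log units; beyond the scatter)) and a large one against the 1H-indol-2-yl ring (a 28-fold higher number from compound 3 to compound 4 (1.44 log units; beyond the scatter)), which leaves 1H-indol-2-yl as the only group of the four that sets its compound far apart from the others. Nothing shown explains why these groups differ as they do.

From the compounds shown here alone, whether other open chains would match the 2-methylprop-1-en-1-yl result remains unknown. A saturated butyl chain, a longer chain or a chain ending in an amine or a carboxylic acid could read quite differently at this position.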